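Moving the chlorine within the aromatic ring

The source may hold more compounds than are shown below. What is called first, only, known or untested is meant among the compounds shown, and "the series" means these compounds.

Of the compounds shown here, three that share one core have been tested in a functional assay on PCO3 cells (Homo sapiens) for cytotoxicity, read by sulforhodamine B assay; a higher number here means a weaker inhibitor of growth, a lower number a stronger inhibitor of growth. Compound 1 `CC1=CC[C@@H]([C@@](C)(O)CCCC(C)(C)NC(=S)N/N=C\c2ccccc2[N+](=O)[O-])CC1` gives 39900 nM, compound 2 `CC1=CC[C@@H]([C@@](C)(O)CCCC(C)(C)NC(=S)N/N=C\c2cccc([N+](=O)[O-])c2)CC1` gives 5600 nM, and compound 3 `CC1=CC[C@@H]([C@@](C)(O)CCCC(C)(C)NC(=S)N/N=C\c2cccc(Cl)c2)CC1` gives 11300 nM. Compound 3 therefore holds the second highest number of the three: compound 2 lies nearest, with a gap that stays within the usual scatter, while compound 1 lies furthest, with a gap beyond it.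

Compound 4 `CC1=CC[C@@H]([C@@](C)(O)CCCC(C)(C)NC(=S)N/N=C\c2ccc(Cl)cc2)CC1` differs from compound 3 in one place: 4-chlorophenyl in place of 3-chlorophenyl on a carbon with a double bond to nitrogen. Among the measured compounds shown here, no measured step moves a chlorine between positions, so the closest guides are indirect. The step of a 7.1-fold lower number from compound 1 to compound 2 (0.85 log units; beyond the scatter) shows that shifting a nitro group within the ring can change the number by a modest amount, whereas the step of a 2.0-fold higher number from compound 2 to compound 3 (0.30 log units; within the scatter) shows that exchanging nitro for chloro at one position changes little. For the measured compounds named here, because a 2.0-fold higher number from compound 2 to compound 3 (0.30 log units; within the scatter) is small and the only positional precedent is modest, a small step in this assay is expected for compound 4, in either direction and probably within the scatter. Compound 4 is estimated at 9000 nM, with a range from 3500 nM to 25000 nM. The step this estimate implies is expected to be a 1.3-fold lower number from compound 3 to compound 4 (0.10 log units; within the scatter).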

Compound 4, concentration for 50% growth inhibition: 7580 nM
For compound 4 the middle estimate is 1.2-fold (0.07 log units) above the measured one; the measured number falls inside the stated range.
By their numbers in this assay, from the lowest: compounds 2, 4 and 3 (each within the scatter of the next); then compound 1.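

Among the compounds shown here, compound 3 and compound 4 give the first direct reading of a chlorine moved around the ring: in this assay, placing 4-chlorophenyl where 3-chlorophenyl stood on the carbon with a double bond to nitrogen gives a 1.5-fold lower number from compound 3 to compound 4 (0.17 log units; within the scatter), so this move makes no difference that the assay can resolve. The new compound also cannot be told apart from the nitro compound, with a 1.4-fold higher number from compound 2 to compound 4 (0.13 log units; within the scatter) for 4-chlorophenyl in place of 3-nitrophenyl, so compound 2, compound 3 and compound 4 form one group in which neither the chlorine's location nor the exchange of these two substituted rings separates the numbers. Only the 2-nitrophenyl compound stands apart, with a 5.3-fold lower number from compound 1 to compound 4 (0.72 log units; beyond the scatter) when 4-chlorophenyl replaces that ring, which makes compound 1 the single clear outlier among these four compounds.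

No measurement of any property of these groups is available to account for these numbers. On these data alone, whether a ring carrying an amine or a carboxylic acid in place of the chlorine would stay with compound 2, compound 3 and compound 4, or shift as far as compound 1, remains open.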